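A few compounds are considered here, and "the series" means these few. Any claim that something is new, unique, unknown or untested is made for them only; others in the source may bear on it.

Compound 1 `COc1cccc2c1c(C(=O)/C=C(\O)C(=O)O)cn2Cc1ccc(F)c(F)c1` gives 71000 nM in an ADME assay on MT4 cells (Homo sapiens) for cytotoxicity, read by MTT assay; on this read-out higher numbers stand for lower toxicity in this test and lower numbers for higher toxicity in this test.
Compound 2 `CCOC(=O)/C(O)=C/C(=O)c1cn(Cc2ccc(F)c(F)c2)c2cccc(OC)c12` gives 125000 nM in this assay.
Compound 3 `COc1cccc2c1c(C(=O)/C=C(\O)C(=O)O)cn2Cc1cccc(F)c1F` gives 17500 nM in this assay.

Of these three numbers, compound 2 has the highest, with compound 1 nearest (a 1.8-fold higher number from compound 1 to compound 2 (0.25 log units; within the scatter), so the two are not separable) and compound 3 furthest. The next compound, compound 4 `CCOC(=O)/C(O)=C/C(=O)c1cn(Cc2ccc(F)cc2F)c2cccc(OC)c12`, differs from compound 2 by 2,4-difluorophenyl in place of 3,4-difluorophenyl on a saturated chain carbon bound to an aromatic nitrogen. Within the data shown here, no measured pair carries this exact exchange. Among the measured compounds shown here, the only step that moves the fluorines on that ring is a 4.1-fold lower number from compound 1 to compound 3 (0.61 log units; beyond the scatter), a modest fall on the acid. Compound 4 is therefore expected to sit somewhat lower than compound 2, with a step of about a 2.1-fold lower number from compound 2 to compound 4 (0.32 log units; beyond the scatter), though the spread allows no change at all. Compound 4 is estimated at 60000 nM, between 25000 nM and 150000 nM.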

Compound 4, half-maximal cytotoxic concentration: 65500 nM
Compound 4: middle estimate off by 1.1-fold (0.04 log units), on the low side; low and high end bracket the measured number.
By their numbers in this assay, from the lowest: compound 3; then compounds 4, 1 and 2 (each within the scatter of the next).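

In this assay, moving the fluorines from 3,4-difluorophenyl to 2,4-difluorophenyl on the ester gives a 1.9-fold lower number from compound 2 to compound 4 (0.28 log units; within the scatter), so this exchange does not separate the two compounds. The earlier compounds shown here showed only a different fluorine move on the acid, a 4.1-fold lower number from compound 1 to compound 3 (0.61 log units; beyond the scatter), and that step lay beyond the scatter. Nothing given here explains the result.

Going by these compounds, what remains open is how 2,4-difluorophenyl behaves on the acid and how 2,3-difluorophenyl behaves on the ester. A plain phenyl or a chlorophenyl in this place also remains an open case.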